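The source may hold more compounds than are shown below. What is called first, only, known or untested is meant among the compounds shown, and "the series" means these compounds.

Working notes on the series. Compound 2 `O=c1c(-c2ccc(F)cc2)c[nH]c2ccnc(Nc3ccc(Oc4ccnc5cc(O)ccc45)c(F)c3)c12` carries a free hydroxy on its aromatic oxygen; in an ADME assay on microsomes from liver (Rattus norvegicus) for metabolic stability (on this read-out lower numbers stand for a shorter-lived compound and higher numbers for a longer-lived compound), compound 2 gives 0.893 h. For the measured compounds named here, its only measured neighbour is compound 1 `O=c1c(-c2ccc(F)cc2)c[nH]c2ccnc(Nc3ccc(Oc4ccnc5cc(OCCO)ccc45)c(F)c3)c12`, which in this assay gives 1.51 h, and the step of a 1.7-fold lower number from compound 1 to compound 2 (0.23 log units; within the scatter) places the two within the scatter of one another, so no order between them can be claimed.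

Compound 3 `CC(O)COc1ccc2c(Oc3ccc(Nc4nccc5[nH]cc(-c6ccc(F)cc6)c(=O)c45)cc3F)ccnc2c1` is the next member. It differs from compound 2 in one place: 2-hydroxypropyl in place of hydrogen on an oxygen on an aromatic ring. Going by the values given here, the only step that bears on this is the one from compound 1 to compound 2, which removed a 2-hydroxyethyl from the same oxygen and moved the number by a 1.7-fold lower number from compound 1 to compound 2 (0.23 log units; within the scatter); a 2-hydroxypropyl entering at that oxygen is the nearest counterpart, so any step in this assay is expected to be small, if anything towards compound 1, and the expected step is a 1.5-fold higher number from compound 2 to compound 3 (0.16 log units; within the scatter). Compound 3 is therefore estimated in this assay at 1.3 h, with a range from 0.6 h to 2.8 h, before its own measurement is known.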

Compound 3, half-life: 1.42 h
Beside the measured number, compound 3's estimate is 1.1-fold (0.04 log units) below it; the measured number falls inside the stated range.
By their numbers in this assay, from the lowest: compounds 2, 3 and 1 (each within the scatter of the next).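

Both new steps stay within the scatter in this assay. The step of a 1.6-fold higher number from compound 2 to compound 3 (0.20 log units; within the scatter) shows that a second chain, 2-hydroxypropyl, on the oxygen on an aromatic ring reads like the 2-hydroxyethyl of compound 1, so neither chain can be ordered against the free hydroxy of compound 2. The comparison of the two chains is new, and the step of a 1.1-fold lower number from compound 1 to compound 3 (0.03 log units; within the scatter) shows that a methyl in place of hydrogen on the saturated chain carbon leaves compound 3 and compound 1 indistinguishable on this read-out. Nothing at hand explains why these three compounds read alike.

Going by these compounds, it remains open whether an amine, a carboxylic acid or a longer chain on this oxygen would give a step beyond the scatter, since the three compounds here span only a free hydroxy and two short hydroxy-bearing chains. Also open is how an ethyl or propyl chain carrying no hydroxy would read, so the part played by the hydroxy of these chains cannot be judged from the compounds shown.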